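Shrinking the azole-fused ring on a ketone-linked side chain

The compounds below may be only part of what the source reports. "The series", "measured", "known", "first", "only" and "open" are said of these compounds alone.

Measured compounds:
Compound 1 `CCCCCCCCc1ccc(OCC(=O)Cn2ncc3ccccc32)cc1` gives 2300 nM.
Compound 2 `CCCCCCCCc1ccc(OCC(=O)Cn2ncc3cccnc32)cc1` gives 1600 nM.
Compound 3 `CCCCCCCCc1ccc(OCC(=O)Cn2ccc3ncccc32)cc1` gives only a limit, > 10000 nM.

The three compounds share the same core and differ only in the heteroaromatic group on a saturated chain carbon bound to a carbonyl carbon. In an assay on microsomes from brain for inhibition of Fatty-acid amide hydrolase 1 (Rattus norvegicus), read by fluorescence and HPLC, with a stated time of 60 min (on this read-out lower numbers stand for stronger inhibition and higher numbers for weaker inhibition), compound 1 and compound 2 sit close together, and a 1.4-fold lower number from compound 1 to compound 2 (0.16 log units; within the scatter) is within the scatter. Compound 3 is weaker than both: an at least 4.3-fold higher number from compound 1 to compound 3 (0.63 log units; beyond the scatter) and an at least 6.2-fold higher number from compound 2 to compound 3 (0.79 log units; beyond the scatter) are both beyond the scatter, though only a limit is known for compound 3, so its true number could lie anywhere past that point (the limit of > 10000 nM in this assay, at which 1 of the 3 values shown sits).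

Compound 4 `CCCCCCCCc1ccc(OCC(=O)Cn2nccn2)cc1` is not yet measured. It differs from compound 3 by a group of 5 heavy atoms (2 carbon, 3 nitrogen; one five-membered aromatic ring with 3 hetero atoms) in place of a group of 9 heavy atoms (7 carbon, 2 nitrogen; one five-membered aromatic ring with 1 hetero atom, one six-membered aromatic ring with 1 hetero atom), on a saturated chain carbon bound to a carbonyl carbon, that is, a 2H-1,2,3-triazol-2-yl replaces the fused two-ring group. Going by the values given here, none of the measured steps covers a change from a fused group to a single five-membered ring, so the direction is open. Given that compound 3 stands only at a limit, the expected step of an at least 1.6-fold lower number from compound 3 to compound 4 (0.22 log units; that floor lies within the scatter) can only be stated broadly, and any movement back toward the range of compound 1 and compound 2 would be a guess. Compound 4 is estimated in this assay at 6000 nM, with a wide range from 800 nM to 40000 nM.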

Compound 4, half-maximal inhibitory concentration: 100 nM
The estimate for compound 4 lay 60-fold (1.78 log units) above the measured number; the whole stated range lies above it.
By their numbers in this assay, from the lowest: compound 4; then compounds 2 and 1 (each within the scatter of the next). At a limit, above all of these: compound 3.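

At this position a fused two-ring group is not required for inhibition in this assay: the single five-membered 2H-1,2,3-triazol-2-yl gives a 23-fold lower number from compound 1 to compound 4 (1.36 log units; beyond the scatter) and a 16-fold lower number from compound 2 to compound 4 (1.20 log units; beyond the scatter) as it replaces those fused groups. The earlier steps shown here compared fused groups only, and this change in ring size gives compound 4 the lowest number of the four, with each of its steps to the others beyond the scatter. Against compound 3 the change reads as an at least 100-fold lower number from compound 3 to compound 4 (2.00 log units; beyond the scatter), but compound 3 stands only at a limit, so that step is a floor: the limit of > 10000 nM in this assay, at which 1 of the 4 values shown sits.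

Whether the gain follows the three ring nitrogens or the loss of the six-membered ring stays open, with no pyrazol-1-yl or imidazol-1-yl among these compounds to separate the two. On these data alone, how the isomeric 1H-1,2,3-triazol-1-yl or a tetrazol-2-yl would stand in this place also remains unknown.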